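Adding a Chloro Group to Compound 2

The compounds below may be only part of what the source reports. "The series", "measured", "known", "first", "only" and "open" are said of these compounds alone.

- compound 1 `Nc1ccccc1NC(=O)c1ccc(CSC(=S)N2CCN(c3ccccc3)CC2)cc1` gives 2140 nM
- compound 2 `Nc1ccccc1NC(=O)c1ccc(CSC(=S)N2CCc3ccccc32)cc1` gives 2300 nM

In a functional assay on MGC-803 cells (Homo sapiens) for antiproliferative activity, read by CCK-8 assay, with a stated time of 72 h (on this read-out lower numbers stand for stronger inhibition and higher numbers for weaker inhibition), compound 2 gives 2300 nM and stands within the scatter of compound 1, so the two cannot be told apart. Compound 3 `Nc1ccccc1NC(=O)c1ccc(CSC(=S)N2CCc3cc(Cl)ccc32)cc1` differs from compound 2 in one place, with chloro in place of hydrogen on an aromatic carbon. Among the compounds with values here, no measured pair here shows what such a change does. Only a modest shift toward stronger inhibition is therefore expected in this assay, an estimated 1.5-fold lower number from compound 2 to compound 3 (0.19 log units; within the scatter) that may not clear the scatter. Compound 3 is estimated at 1500 nM with an expected range from 550 nM to 4000 nM once measured.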

Compound 3, half-maximal inhibitory concentration: 1890 nM
Compound 3: middle estimate off by 1.3-fold (0.10 log units), on the low side; measured number inside the range.
By their numbers in this assay, from the lowest: compounds 3, 1 and 2 (each within the scatter of the next).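

Chloro in place of hydrogen on this aromatic carbon, turning 2,3-dihydro-1H-indol-1-yl into 5-chloro-2,3-dihydro-1H-indol-1-yl, comes to a 1.2-fold lower number from compound 2 to compound 3 (0.09 log units; within the scatter) in this assay. The position therefore accepts a chlorine atom, but compound 3 and compound 2 cannot be told apart on this read-out. Nothing at hand gives a reason for this result. From the compounds shown here alone, whether another group on this carbon, such as an amine, a carboxylic acid or a methoxy group, would separate from compound 2 remains open. So does the outcome of chloro on another carbon of this ring.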